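The source may report more compounds than this note shows. Statements on the series, on what has been measured and on what is new or still open speak of the compounds shown alone.

Working notes on the series. Compound 1 `CCOC(=O)c1[nH]c(=O)c(C#N)cc1C(=O)c1ccc(Cl)cc1` carries an ethyl ester, a nitrile and a 4-chlorophenyl ketone on the shared core. In an ADME assay on J774.A1 cells (Mus musculus) for cytotoxicity, read by MTT assay, with a stated time of 48 h (on this read-out lower numbers stand for higher toxicity in this test and higher numbers for lower toxicity in this test), compound 1 gives only a limit, < 100000 nM, and no number. That limit is the limit of < 100000 nM in this assay, at which 1 of the 2 values shown sits, so the position of compound 1 within the measured range is not fixed. Compound 2 `O=C(c1ccc([N+](=O)[O-])cc1)c1cc(C(=O)O)c(=O)[nH]c1C(=O)O` differs from compound 1 in more than one place and is not a single step from it. In this assay compound 2 gives 388000 nM.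

The step considered here is compound 1 to compound 3 `CCOC(=O)c1[nH]c(=O)c(C#N)cc1C(=O)c1ccc(OC)cc1`: methoxy in place of chloro on an aromatic carbon. Among the compounds with values here, no measured step of this kind is available in this assay, so the expectation rests on the limit of compound 1 alone. The step from compound 1 to compound 3 is expected to be a step that the limit leaves unreadable from compound 1 to compound 3, a change not clearly beyond the usual scatter in this assay. Compound 3 is therefore estimated at 60000 nM, with a range from 20000 nM to 200000 nM, and a fair chance that this assay again returns only a limit.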

Compound 3, half-maximal cytotoxic concentration: < 100000 nM
Compound 3: no number, only a limit (the forecaster's own chance of this, stated with the estimate: 40%); the middle value lies beyond the limit too.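

Compound 3, like compound 1, returns only a limit in this assay, so no step between the two can be read: the limit of < 100000 nM in this assay, at which 2 of the 3 values shown sit.

The compounds shown leave open whether methoxy in place of chloro on an aromatic carbon shifts the half-maximal cytotoxic concentration at all.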